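This account rests on a few compounds, and the source may have more. Where it says the series, first, only, none or still open, it means among the compounds named here.

Measured so far:

Compound 1 `O=C(Nc1ccc(I)cc1)c1cncc(N2CC3CC(C2)N3)c1` gives 0.366 nM in an assay on membranes from Cerebral cortex for displacement of a labelled ligand from Neuronal acetylcholine receptor; alpha4/beta2 (Rattus norvegicus); on this read-out lower numbers stand for stronger inhibition and higher numbers for weaker inhibition.
Compound 2 `O=C(Nc1ccc(Cl)cc1)c1cncc(N2CC3CC(C2)N3)c1` gives 0.404 nM in this assay.

Going by the values given here, on these two numbers compound 2 and compound 1 cannot be told apart: the only measured step, a 1.1-fold higher number from compound 1 to compound 2 (0.04 log units; within the scatter), sits within the scatter of repeated measurements, so the two values describe essentially the same level of binding.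

Compound 3 `O=C(Nc1cccc(Cl)c1)c1cncc(N2CC3CC(C2)N3)c1` differs from compound 2 in a single place: 3-chlorophenyl in place of 4-chlorophenyl on an amide-type nitrogen. The chlorine stays, but the ring that carries it is attached in a different way.

Among the compounds with values here, the one measured step, from compound 1 to compound 2, concerns a swap of halogen on the same ring position and was small; it says nothing about moving the chlorine to another place on that ring. Within the data shown here, no measured pair addresses such a move. The expectation for this assay therefore rests on the general closeness of the two measured values, and a step in either direction beyond the scatter cannot be excluded, with a modest loss thought somewhat more likely than a gain.

Compound 3 is therefore expected to give 0.6 nM in this assay, with a range from 0.2 nM to 1.8 nM. This estimate corresponds to an expected step of a 1.5-fold higher number from compound 2 to compound 3 (0.17 log units; within the scatter).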

Compound 3, inhibition constant: 0.042 nM
Compound 3: the middle estimate sits 14-fold (1.15 log units) above what was measured, and the stated range ends above it.
By their numbers in this assay, from the lowest: compound 3; then compounds 1 and 2 (each within the scatter of the next).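

In this assay, where the chlorine sits on the phenyl ring on the amide-type nitrogen matters far more than which halogen the ring carries: 3-chlorophenyl in place of 4-chlorophenyl brings a 9.6-fold lower number from compound 2 to compound 3 (0.98 log units; beyond the scatter) and takes the series clearly beyond the level the first two compounds shared. The same holds against the iodo compound, with an 8.7-fold lower number from compound 1 to compound 3 (0.94 log units; beyond the scatter) for 3-chlorophenyl in place of 4-iodophenyl, while the halogen swap alone gave only a 1.1-fold higher number from compound 1 to compound 2 (0.04 log units; within the scatter) and so gave no hint that this ring could move the number at all. Nothing available bears on why the 3-chlorophenyl group gives the lower number.

The compounds shown leave open whether the gain belongs to chlorine itself or would carry over to a 3-iodophenyl group, or to a methoxy group, an amine or a carboxylic acid in the place of the chlorine. They also leave open whether the lower number seen for compound 3 is specific to this receptor or would appear equally on other nicotinic receptor subtypes.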